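Swapping the Thiophene Ring in a Small Series

The source may hold more compounds than are shown below. What is called first, only, known or untested is meant among the compounds shown, and "the series" means these compounds.

Of the compounds shown here, three sharing one core have been measured in a functional assay on cells (Cancer cell lines, Homo sapiens) for inhibition; a higher number here means a weaker inhibitor of growth, a lower number a stronger inhibitor of growth. Compound 1 `N=C(N)N/N=C/c1c(-c2cccs2)nc2n1CCS2` gives 17400 nM, compound 2 `N=C(N)N/N=C/c1c(-c2cccs2)nc2sccn12` gives 14800 nM, and compound 3 `Cc1cn2c(/C=N/NC(=N)N)c(-c3cccs3)nc2s1` gives 5750 nM. Compound 1 therefore carries the highest of the three numbers; its gap to compound 2 lies within the scatter, while its gap to compound 3 lies beyond it. Going by the values given here, the only step between two compounds that differ in one place, a 2.6-fold lower number from compound 2 to compound 3 (0.41 log units; beyond the scatter), concerns a methyl in place of hydrogen and says nothing about the thiophene ring itself.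

Compound 4 `N=C(N)N/N=C/c1c(-c2cc(Cl)sc2Cl)nc2n1CCS2` differs from compound 1 by 2,5-dichlorothiophen-3-yl in place of thiophen-2-yl on an aromatic carbon. Among the compounds with values here, no measured pair shows what such a swap does, so the expectation rests on the narrow spread of the three numbers alone, and no step beyond the scatter is expected. For compound 4 the estimate in this assay is 15000 nM, within a range of 6000 nM to 40000 nM. That estimate means an expected 1.2-fold lower number from compound 1 to compound 4 (0.06 log units; within the scatter).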

Compound 4, concentration for 50% growth inhibition: 12300 nM
Estimate against measurement, compound 4: 1.2-fold (0.09 log units) above; measured number inside the range.
By their numbers in this assay, from the lowest: compound 3; then compounds 4, 2 and 1 (each within the scatter of the next).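

In this assay, going by these compounds alone, the swap gives a 1.4-fold lower number from compound 1 to compound 4 (0.15 log units; within the scatter), the first measured change at this position on the thiophene side of the core. In this one pair, the position carries 2,5-dichlorothiophen-3-yl, with 7 heavy atoms in place of 5, and compound 4 cannot be told apart from compound 1. No measurement shown bears on why this swap leaves the two compounds so close.

This single pair cannot separate the two chlorine atoms from the different attachment of the thiophene, a question that an unsubstituted thiophen-3-yl group could address. Going by these compounds, it also remains open whether a group outside the thiophene family, such as a phenyl ring or an amine, would stay within the scatter of compound 1 at this position.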